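Pentafluoroethyl in Place of Trifluoroethyl: An Expectation

A few compounds are considered here, and "the series" means these few. Any claim that something is new, unique, unknown or untested is made for them only; others in the source may bear on it.

Compound 2 `CS(=O)(=O)Nc1ccc(CNC(=O)c2ccc(CC(F)(F)F)cc2)c(Cl)c1` gives 4000 nM in an assay on HeLa cells for agonist activity at Bile acid receptor (Homo sapiens), read by a luciferase reporter, with a stated time of 24 h (on this read-out lower numbers stand for an effect already at smaller amounts and higher numbers for an effect only at larger amounts of compound), the higher of the two numbers recorded so far. Compound 1 `CCOc1ccc(C(=O)NCc2ccc(NS(C)(=O)=O)cc2Cl)cc1` gives 2200 nM, and the step of a 1.8-fold higher number from compound 1 to compound 2 (0.26 log units; within the scatter) stays within the scatter. Compound 3 `CS(=O)(=O)Nc1ccc(CNC(=O)c2ccc(C(F)(F)C(F)(F)F)cc2)c(Cl)c1` carries 1,1,2,2,2-pentafluoroethyl in place of 2,2,2-trifluoroethyl on an aromatic carbon. Within the data shown here, only that earlier step, an ethoxy replaced by a fluorinated chain, bears on this change, and it was small, so no shift beyond the scatter is expected. The estimated step is no change at the digits printed from compound 2 to compound 3 (within the scatter). Compound 3 is therefore expected to give 4000 nM, within a range from 1500 nM to 11000 nM.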

Compound 3, half-maximal effective concentration: 3220 nM
The estimate for compound 3 lay 1.2-fold (0.09 log units) above the measured number; the range from low to high includes it.
By their numbers in this assay, from the lowest: compounds 1, 3 and 2 (each within the scatter of the next).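

At this place, on an aromatic carbon para to a large group, 1,1,2,2,2-pentafluoroethyl in this assay gives a 1.2-fold lower number from compound 2 to compound 3 (0.09 log units; within the scatter) against 2,2,2-trifluoroethyl, and a 1.5-fold higher number from compound 1 to compound 3 (0.17 log units; within the scatter) against ethoxy. The three groups of compound 1, compound 2 and compound 3 therefore cannot be told apart at this place in this assay. No measurement offered here accounts for this. Still open, as far as these compounds go, is whether an amine, a carboxylic acid or a longer chain at this place would move the number beyond the scatter, and whether this sameness would hold on a changed core.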